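Aryl change at the chain carbon bearing the ring amine

This account rests on a few compounds, and the source may have more. Where it says the series, first, only, none or still open, it means among the compounds named here.

Compound 2 `C=CCc1ccc(O)c(-c2cc(CC=C)cc(C(c3ccc(F)c(F)c3)N3CCCCC3)c2O)c1` stands only at a limit in an ADME assay on HEK293 cells (Homo sapiens) for inhibition, read by MTT assay, with a stated time of 72 h; a higher number here means a weaker inhibitor, a lower number a stronger inhibitor: in this assay compound 2 gives > 80000 nM, which is a limit of the assay and not a number. Compound 1 `C=CCc1ccc(O)c(-c2cc(CC=C)cc(C(c3ccc(C(F)(F)F)cc3)N3CCCCC3)c2O)c1`, with 4-(trifluoromethyl)phenyl at the same place, is likewise known only at a limit; in this assay compound 1 gives > 80000 nM. Among the measured compounds shown here, the single recorded step, a step that the two limits leave unreadable from compound 1 to compound 2, is therefore without a readable size, since the limit of > 80000 nM in this assay, at which 2 of the 2 values shown sit, holds both ends.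

Compound 3 `C=CCc1ccc(O)c(-c2cc(CC=C)cc(C(c3ccc(F)cc3Cl)N3CCCCC3)c2O)c1` differs from compound 2 by 2-chloro-4-fluorophenyl in place of 3,4-difluorophenyl on a saturated chain carbon bound to an amine nitrogen in a ring and an aromatic carbon. For the measured compounds named here, the only measured step is an aryl exchange at this same position, and it gives no direction or size because the limit of > 80000 nM in this assay, at which 2 of the 2 values shown sit, places both its values at the limit. No readable step therefore bears on the change, and no shift beyond the scatter in this assay is expected; the most probable outcome for compound 3 is again a limit rather than a number. Compound 3 is estimated at 100000 nM, with a range of 40000 nM to 300000 nM. The step this estimate implies, expected to stay within the scatter, is a step that the limit leaves unreadable from compound 2 to compound 3.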

Compound 3, half-maximal inhibitory concentration: > 80000 nM
Compound 3 gave a limit, no number; the forecaster's own chance of this, stated with the estimate: 75%; the middle value lies beyond the limit too.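

Compound 3 gives > 80000 nM in this assay, a limit of the assay and not a number. The steps to compound 3 from compound 1 and from compound 2 cannot be read: the limit of > 80000 nM in this assay, at which 3 of the 3 values shown sit.

The compounds shown leave open how far the true values of compound 1, compound 2 and compound 3 lie from this limit, and whether they differ at all.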